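This account rests on a few compounds, and the source may have more. Where it says the series, first, only, none or still open, it means among the compounds named here.

Compound 1 `C=C[C@@](C)(/C=C/c1ccc(O)cc1)CC/C=C/C(=O)c1ccccc1` carries a benzoyl group on a double-bonded chain carbon bound to a double-bonded chain carbon. In a functional assay on NALM-6 cells (Homo sapiens) for cytotoxicity, with a stated time of 72 h (on this read-out lower numbers stand for an effect already at smaller amounts and higher numbers for an effect only at larger amounts of compound), compound 1 gives only a limit, > 43400 nM. Compound 2 `C=C[C@@](C)(/C=C/c1ccc(O)cc1)CC/C=C/C#N` differs from compound 1 in one place: cyano in place of benzoyl on a double-bonded chain carbon bound to a double-bonded chain carbon. In this assay compound 2 likewise gives only a limit, > 43400 nM. The step that the two limits leave unreadable from compound 1 to compound 2 therefore cannot be read, as both numbers sit at the limit of > 43400 nM in this assay, at which 2 of the 3 values shown sit.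

Compound 3 `C=C[C@@](C)(/C=C/c1ccc(O)c(/C=C/C(=O)c2ccccc2)c1)CCC=C(C)C` is built on a different core; how the two cores differ is not broken down here. In this assay, for the measured compounds named here, compound 3 gives 4470 nM, the only number among the three measured compounds. Compound 4 `C=C[C@@](C)(/C=C/c1ccc(O)c(/C=C/C#N)c1)CCC=C(C)C` has not yet been measured. It differs from compound 3 by the same change that separates compound 2 from compound 1: cyano in place of benzoyl on a double-bonded chain carbon bound to a double-bonded chain carbon.

For compound 4 the step of a 2.7-fold higher number from compound 3 to compound 4 (0.43 log units; beyond the scatter) is estimated, resting on a weak basis, since the comparable change from compound 1 to compound 2 left both values at a limit. Compound 4 is expected to give about 12000 nM, with a wide range from 3500 nM to 40000 nM.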

Compound 4, half-maximal effective concentration: > 43400 nM
Compound 4: no number, only a limit; the forecaster's own chance of this, stated with the estimate: 40%; at least 3.6-fold (0.55 log units) between middle value and limit.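

In this assay, putting cyano in place of benzoyl on the core of compound 3 gives an at least 9.7-fold higher number from compound 3 to compound 4 (0.98 log units; beyond the scatter), so on this core the benzoyl compound acts at smaller amounts than the cyano compound. Compound 4 gives only a limit, which makes this step a minimum size and not an exact one. The same change on the core of compound 1 cannot be read, and so the series does not show whether the change behaves alike on both cores, because compound 1 and compound 2 stand at a limit, as does compound 4: the limit of > 43400 nM in this assay, at which 3 of the 4 values shown sit.

Benzoyl and cyano are the only groups shown at this place, so it stays open how an amine, a carboxylic acid or a longer chain there would read in this assay. As far as these compounds go, the step swaps the whole benzoyl group at once, and it also stays open whether its aromatic ring or its carbonyl matters more.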